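Swapping allyl for 4-methylphenyl on a weakly active compound

The compounds below may be only part of what the source reports. "The series", "measured", "known", "first", "only" and "open" are said of these compounds alone.

Compound 1 (`C=CC/N=C1\S/C(=C\c2ccc(OC)cc2)C(=O)N1C`) sits at the weak end of a functional assay on MCF7 cells (Homo sapiens) for antiproliferative activity, read by MTT assay, with a stated time of 72 h (a lower number here means a stronger inhibitor, a higher number a weaker inhibitor), with > 100000 nM as its entry, and that entry is a limit of the assay, not a number. Compound 2 (`S=C(Nc1ccccc1)N1C/C(=C/c2ccccc2)S/C1=N\c1ccccc1`) likewise shows > 100000 nM as its entry, which is again a limit. Only compound 3 (`COc1ccc(/C=C2\S/C(=N\c3cc(C(F)(F)F)cc(C(F)(F)F)c3)N(C)C2=O)cc1`) gives a true number, with 77800 nM as its reading, so activity across these three compounds is weak.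

Compound 4 (`COc1ccc(/C=C2\S/C(=N\c3ccc(C)cc3)N(C)C2=O)cc1`) has not yet been measured. It comes from compound 1 by putting 4-methylphenyl in place of allyl on a double-bonded nitrogen. Among the compounds with values here, no two measured compounds differ in just one place, so there is no direct precedent for the size of this change. Within the data shown here, the expectation rests on compound 3 with 77800 nM as the one measured number, and that number gives no reason to predict a large gain. The estimated step is an at least 1.4-fold lower number from compound 1 to compound 4 (0.15 log units; that floor lies within the scatter) and it is expected to be small, in the direction of stronger inhibition. Compound 4 may also return only a limit. In this assay the expected value for compound 4 is 70000 nM with an estimated range from 25000 nM to 150000 nM around it.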

Compound 4, half-maximal inhibitory concentration: > 100000 nM
Compound 4: a limit, no number; the forecaster's own chance of this, stated with the estimate: 40%; middle value at least 1.4-fold (0.15 log units) from the limit.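

No step can be read between compound 1 and compound 4, as each gives only a limit in this assay, not a number. Both entries sit at the same point: the limit of > 100000 nM in this assay, at which 3 of the 4 values shown sit.

The compounds shown leave open whether 4-methylphenyl in place of allyl on a double-bonded nitrogen changes activity at all, and by how much.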